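Tosyl-piperidine series: chain length at the ring carbon

This account rests on a few compounds, and the source may have more. Where it says the series, first, only, none or still open, it means among the compounds named here.

Compound 1 `Cc1ccc(S(=O)(=O)N2CC[C@@H](Br)C[C@@H]2CC(C)C)cc1` is the reference point of this set. In a functional assay on SW1573 cells (Homo sapiens) for antiproliferative activity, read by sulforhodamine B assay, with a stated time of 48 h (a higher number here means a weaker inhibitor of growth, a lower number a stronger inhibitor of growth), compound 1 gives 22000 nM. Compound 2 `CCCCCCC[C@H]1C[C@H](Br)CCN1S(=O)(=O)c1ccc(C)cc1` carries the change (hexyl in place of isopropyl on a saturated chain carbon bound to a saturated ring carbon). For compound 2 this assay reports only a limit, > 100000 nM, so the step is read as a bound: an at least 4.5-fold higher number from compound 1 to compound 2 (0.65 log units; beyond the scatter). What bears on that step is the limit of > 100000 nM in this assay, at which 1 of the 3 values shown sits.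

Compound 3 `Cc1ccc(S(=O)(=O)N2CCC(Br)=CC2CC(C)C)cc1` has a different core; the difference between the core of compound 1 and the core of compound 3 is not broken down here. In this assay compound 3 gives 26000 nM, which sits within the scatter of the value of compound 1.

Compound 4 `CCCCCCCC1C=C(Br)CCN1S(=O)(=O)c1ccc(C)cc1` is not yet measured. Going by the values given here, it differs from compound 3 by hexyl in place of isopropyl on a saturated chain carbon bound to a saturated ring carbon, the same change, made at the same place, as the one from compound 1 to compound 2. The expected step is a 4.6-fold higher number from compound 3 to compound 4 (0.66 log units; beyond the scatter), resting on the measured step of an at least 4.5-fold higher number from compound 1 to compound 2 (0.65 log units; beyond the scatter) and the similar starting values of compound 1 and compound 3. For compound 4 the expected value in this assay is 120000 nM, with a likely range from 50000 nM to 300000 nM, and a real chance that only a limit is reported.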

Compound 4, concentration for 50% growth inhibition: 49000 nM
Beside the measured number, compound 4's estimate is 2.4-fold (0.39 log units) above it; measured number outside the range, below it.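

Hexyl in place of isopropyl on the core of compound 3 reads in this assay as a 1.9-fold higher number from compound 3 to compound 4 (0.28 log units; within the scatter), so on this core the change gives no step that can be told from the scatter. This shows neither that the change carries from one core to the other with the same size nor that its size depends on the core: the same change on two cores in this assay, an at least 4.5-fold higher number (0.65 log units; beyond the scatter) from compound 1 to compound 2 and a 1.9-fold higher number (0.28 log units; within the scatter) from compound 3 to compound 4; the limit leaves it open whether they differ. Compound 2 is known only as a limit, > 100000 nM.

Only isopropyl and hexyl are shown at this place, so it stays open how a shorter chain such as ethyl, or a chain ending in an amine or a carboxylic acid, would read on either core. Also open, from the compounds shown here alone, is whether the change would read the same way on a core with a nitrile in place of the bromine, and a numerical value for compound 2 would be needed before the two steps could be compared.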